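This account rests on a few compounds, and the source may have more. Where it says the series, first, only, none or still open, it means among the compounds named here.

Working notes on the series.

Compound 3 `CC(C)c1nc2c(C(=O)NCC3CCN(CCN4CCN(S(C)(=O)=O)CC4)CC3)cccc2[nH]1` gives 64% in a functional assay for agonist activity at 5-hydroxytryptamine receptor 4 (Homo sapiens), read by cAMP accumulation; on this read-out lower numbers stand for smaller maximal responses and higher numbers for larger maximal responses. It stands level with compound 2 `CC(=O)N(C)CC(O)CN1CCC(CNC(=O)c2cccc3[nH]c(C(C)C)nc23)CC1`, which gives 64%; together they are the lowest of the three numbers, and the step of no change at the digits printed from compound 2 to compound 3 (within the scatter) lies within the scatter. Compound 1 `CC(=O)N1CCN(CCN2CCC(CNC(=O)c3cccc4[nH]c(C(C)C)nc34)CC2)CC1` gives 76%, with a number 12 percentage points lower from compound 1 to compound 3 (beyond the scatter) and a number 12 percentage points lower from compound 1 to compound 2 (beyond the scatter), both modest but beyond the scatter.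

Compound 4 `COC(=O)N(C)CC(O)CN1CCC(CNC(=O)c2cccc3[nH]c(C(C)C)nc23)CC1` is not yet measured. It differs from compound 3 as follows: 1-hydroxy-2-((methoxycarbonyl)(methyl)amino)ethyl in place of (4-(methylsulfonyl)piperazin-1-yl)methyl on a saturated chain carbon bound to an amine nitrogen in a ring. The step that bears most directly on this is no change at the digits printed from compound 2 to compound 3 (within the scatter), which exchanged the same ring-containing group for the open-chain one with no change beyond the scatter. Going by the values given here, compound 4 carries the open chain of compound 2 with methoxycarbonyl where compound 2 has acetyl; for that exchange no step is recorded, and the only neighbouring exchange on this series, a number 12 percentage points lower from compound 1 to compound 3 (beyond the scatter), was modest. The expectation is therefore a step of no change at the digits printed from compound 3 to compound 4 (within the scatter) within the scatter, in no particular direction.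

Compound 4 is expected to give 64%, in the range 50% to 78%.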

Compound 4, intrinsic activity: the largest response reached, in percent of the reference agonist's: 64%
For compound 4 middle estimate and measured number coincide at the digits printed; the range from low to high includes it.
By their numbers in this assay, from the lowest: compounds 2, 3 and 4 (each within the scatter of the next); then compound 1.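

Methoxy in place of methyl on the carbonyl carbon of the open chain is a new kind of exchange in this series, and in this assay it leaves the maximal response level (no change at the digits printed from compound 2 to compound 4 (within the scatter)). The open chain therefore holds that level with either acetyl or methoxycarbonyl, and with methoxycarbonyl it also stays level with the (4-(methylsulfonyl)piperazin-1-yl)methyl group (no change at the digits printed from compound 3 to compound 4 (within the scatter)). Among the groups at this place, on a saturated chain carbon bound to an amine nitrogen in a ring, only the (4-acetylpiperazin-1-yl)methyl group of compound 1 stands apart (a number 12 percentage points lower from compound 1 to compound 4 (beyond the scatter)).

Nothing at hand gives a reason for these levels. Still open, as far as these compounds go, is whether an amine or a carboxylic acid on that carbonyl carbon, or a longer chain in place of the open chain, would hold the same level.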